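The source may hold more compounds than are shown below. What is called first, only, known or untested is meant among the compounds shown, and "the series" means these compounds.

Working notes on the series. Among the compounds with values here, in a functional assay on MCF7 cells (Homo sapiens) for antiproliferative activity, read by MTT assay (on this read-out higher numbers stand for weaker inhibition and lower numbers for stronger inhibition), compound 2 (`O=[N+]([O-])c1ccc(Nc2nccc(-c3ccc(Br)cc3)n2)cc1`) gives 681000 nM, the highest number of the three measured so far. Compound 3 (`Clc1ccc(Nc2nccc(-c3ccc(Br)cc3)n2)cc1`) gives 4180 nM and compound 1 (`COc1ccc(-c2ccnc(Nc3ccc(Cl)cc3Cl)n2)cc1`) gives 4170 nM, two values within the scatter of each other. Within the data shown here, the only measured step between compounds differing in one place is large: a 160-fold lower number from compound 2 to compound 3 (2.21 log units; beyond the scatter), with chloro in place of nitro on an aromatic carbon.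

Compound 4 (`O=[N+]([O-])c1ccc(Nc2nccc(-c3ccc(Cl)cc3Cl)n2)cc1`) keeps the nitro group of compound 2 and changes a different place: 2,4-dichlorophenyl in place of 4-bromophenyl on an aromatic carbon. This puts 2,4-dichlorophenyl in place of 4-bromophenyl. Among the measured compounds shown here, no measured step covers this place. Compound 1 also carries 2,4-dichlorophenyl, but elsewhere, and it differs from compound 2 in more than one place. The step to compound 3 therefore bears only indirectly, showing how far this assay can move within the series but not how far this change will move it. Compound 2 stands well apart at 681000 nM, so some drift toward the other two compounds is expected, though far less than the measured step and with wide uncertainty. The expected change is a 6.8-fold lower number from compound 2 to compound 4 (0.83 log units; beyond the scatter). Compound 4 is estimated at 100000 nM, with an expected range of 5000 nM to 700000 nM.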

Compound 4, half-maximal inhibitory concentration: 192000 nM
Compound 4: middle estimate off by 1.9-fold (0.28 log units), on the low side; the measured number falls inside the stated range.
By their numbers in this assay, from the lowest: compounds 1 and 3 (each within the scatter of the next); then compound 4; then compound 2.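

Within the data shown here, this is the first measured step at this place, the aromatic carbon of the six-membered aromatic ring with 2 nitrogen, and in this assay it reads a 3.5-fold lower number from compound 2 to compound 4 (0.55 log units; beyond the scatter), so the number does respond to 2,4-dichlorophenyl in place of 4-bromophenyl with the nitro group kept. The step is modest beside the large 160-fold lower number from compound 2 to compound 3 (2.21 log units; beyond the scatter), which was taken in a different place, and compound 4 at 192000 nM still carries the nitro group. Nothing on hand accounts for the shift at this place.

The compounds shown leave open whether this step carries over to a partner with chloro in place of nitro, as both one-place changes are seen only from compound 2, so it remains unknown whether the two changes add up, partly overlap or interact. Among these compounds, also open is how this place reads with a phenyl ring bearing an amine or a carboxylic acid, or with a longer alkyl chain in place of the phenyl ring, as only two halogen-bearing phenyl groups have been compared here.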